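The source may report more compounds than this note shows. Statements on the series, on what has been measured and on what is new or still open speak of the compounds shown alone.

Measured in an ADME assay on MT4 cells (Homo sapiens) for cytotoxicity, read by MTT assay; on this read-out higher numbers stand for lower toxicity in this test and lower numbers for higher toxicity in this test:
- compound 1 `CCCC1C(=O)N(O)C(=O)c2ccccc21`: 25400 nM
- compound 2 `O=C1c2ccccc2C(Cc2ccc(C(F)(F)F)cc2)C(=O)N1O`: 6000 nM

Compound 1 stands highest of the two, clearly beyond the scatter from compound 2. Compound 3 `CC1C(=O)N(O)C(=O)c2ccccc21` carries methyl where compound 1 carries propyl: hydrogen in place of ethyl on a saturated chain carbon bound to a saturated ring carbon. Going by the values given here, no measured step isolates this change, so the expectation rests only on these two values. In this assay, a small upward shift or none beyond the scatter is expected. The estimated change is a 1.5-fold higher number from compound 1 to compound 3 (0.17 log units; within the scatter). For compound 3 the expected value is 38000 nM, with an estimated range of 15000 nM to 100000 nM.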

Compound 3, half-maximal cytotoxic concentration: 250000 nM
Beside the measured number, compound 3's estimate is 6.6-fold (0.82 log units) below it, outside the stated range (above it).
By their numbers in this assay, from the lowest: compound 2; then compound 1; then compound 3.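

Cutting propyl to methyl at this position is not a silent change in (this assay) but a shift towards lower toxicity in this test (a 9.8-fold higher number from compound 1 to compound 3 (0.99 log units; beyond the scatter)). With the shared core unchanged, the number at this saturated ring carbon responds to the length of the chain alone. No measurement at hand gives a cause for this step.

On these data alone, whether the number follows chain length stepwise stays open, and an ethyl or butyl chain at this carbon would test that. Also open, as far as these compounds go, is whether an amine or a carboxylic acid on the chain would keep the higher number seen with methyl.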